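Benzyl for cyclohexyl on the ring nitrogen of compound 3

This account rests on a few compounds, and the source may have more. Where it says the series, first, only, none or still open, it means among the compounds named here.

Three compounds of the series have numbers in a functional assay on CCRF-CEM cells (Homo sapiens) for inhibition, read by sulforhodamine B assay, with a stated time of 48 h, tested at 10 uM; on this read-out lower numbers stand for less inhibition and higher numbers for more inhibition at the one concentration tested (going by the name of the read-out). Compound 1 `c1ccc2c(-c3cn4ccnc4c(-c4ccc5ncn(C6CCCCC6)c5c4)n3)cccc2c1` gives 17.5%, and compound 2 `Fc1ccccc1-c1cn2ccnc2c(-c2ccc3ncn(C4CCCCC4)c3c2)n1` gives 22.5%. Among the compounds with values here, the step of a number 5 percentage points higher from compound 1 to compound 2 (within the scatter) is the only single-point step measured so far, and it sits on an aromatic carbon, not on the ring nitrogen. Compound 3 `c1cn2cc(-c3ccc4c(c3)ncn4C3CCCCC3)nc(-c3ccc4ncn(C5CCCCC5)c4c3)c2n1` gives 46.1% and stands highest of the three, with compound 2 nearest and compound 1 furthest, both gaps beyond the scatter.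

Compound 4 `c1ccc(Cn2cnc3ccc(-c4nc(-c5ccc6c(c5)ncn6C5CCCCC5)cn5ccnc45)cc32)cc1` is not yet measured. It differs from compound 3 by benzyl in place of cyclohexyl on an aromatic nitrogen. Within the data shown here, no measured step touches this ring nitrogen, so the measured steps give no direct guide to the size or direction of the change; the only precedent concerns a different position and lies within the scatter. The expectation for compound 4 is therefore a step of a number 6.1 percentage points lower from compound 3 to compound 4 (within the scatter) with no clear direction, and the estimate for compound 4 is 40%, between 18% and 62%, a wide range given the absence of a bearing step.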

Compound 4, a percentage reported as inhibition, at one concentration (the size of the read-out at that concentration, not a potency): 94.4%
Estimate against measurement, compound 4: 54.4 percentage points below; the whole stated range lies below it.
By their numbers in this assay, from the lowest: compounds 1 and 2 (each within the scatter of the next); then compound 3; then compound 4.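

In this assay, within the data shown here, the aromatic nitrogen of the five-membered aromatic ring proves a sensitive place: benzyl in place of cyclohexyl gives a number 48.3 percentage points higher from compound 3 to compound 4 (beyond the scatter) and is the first single-place change to move the number beyond the scatter, whereas the earlier step gives only a number 5 percentage points higher from compound 1 to compound 2 (within the scatter) on an aromatic carbon. The change swaps a six-membered non-aromatic ring for a six-membered aromatic ring and adds one carbon, with no hydrogen-bond donors or acceptors on either group. Nothing at hand bears on the reason for this step.

On these data alone, whether the ring type or the added carbon carries the gain stays open; phenyl or 2-phenylethyl at this nitrogen would separate the two. Also open, as far as these compounds go, is how a dimethylaminomethyl or carboxylic acid group on the benzyl ring would read.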